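The compounds below may be only part of what the source reports. "The series", "measured", "known", "first", "only" and "open" are said of these compounds alone.

Measured so far in a functional assay on OVCAR-8 cells (Homo sapiens) for antiproliferative activity; a lower number here means a stronger inhibitor, a higher number a weaker inhibitor:
- compound 1 `Cn1ncc(Cl)c1-c1cc(C(=O)N[C@@H]2CNCC[C@H]2c2ccc(C(F)(F)F)cc2)oc1Cl`: 120 nM
- compound 2 `Cn1ncc(Cl)c1-c1cc(C(=O)N[C@@H]2CN[C@H](CCO)C[C@H]2c2ccc(F)c(F)c2)oc1Cl`: 460 nM
- compound 3 `Cn1ncc(Cl)c1-c1cc(C(=O)N[C@@H]2CN[C@H](CCO)C[C@H]2c2ccc(Cl)c(Cl)c2)oc1Cl`: 610 nM

Compound 2 holds the middle place of these three numbers, although its distance from compound 3 lies within the scatter. The number for compound 1 (120 nM) is clearly lower than that of compound 2 (460 nM), a gap beyond the scatter.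

Compound 4 `CC(=O)OCC[C@@H]1C[C@@H](c2ccc(F)c(F)c2)[C@H](NC(=O)c2cc(-c3c(Cl)cnn3C)c(Cl)o2)CN1` is the next to be tested in this assay. It differs from compound 2 by acetyl in place of hydrogen on an oxygen on a saturated carbon, which turns 2-hydroxyethyl into 2-acetoxyethyl.

Among the compounds with values here, no measured step touches this oxygen. Within the data shown here, the only step available (a 1.3-fold higher number from compound 2 to compound 3 (0.12 log units; within the scatter)) replaces 3,4-difluorophenyl with 3,4-dichlorophenyl elsewhere in the molecule, so it bears on this change only indirectly. It shows a swap that leaves the number within the scatter, but it says nothing about the direction of the new change.

No shift beyond the scatter is therefore expected, and the estimated step is small (a 1.1-fold lower number from compound 2 to compound 4 (0.04 log units; within the scatter)). For compound 4 the expected value is 420 nM in a deliberately wide estimated range (140 nM to 1300 nM).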

Compound 4, half-maximal inhibitory concentration: 4960 nM
Compound 4: middle estimate off by 12-fold (1.07 log units), on the low side; the whole stated range lies below it.
By their numbers in this assay, from the lowest: compound 1; then compounds 2 and 3 (each within the scatter of the next); then compound 4.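

In this assay, placing acetyl on the oxygen of the 2-hydroxyethyl group gives an 11-fold higher number from compound 2 to compound 4 (1.03 log units; beyond the scatter), the first sign that this position responds strongly to change. Within the data shown here, the only earlier step between compounds differing in one place, a 1.3-fold higher number from compound 2 to compound 3 (0.12 log units; within the scatter), concerned the aryl group on a saturated ring carbon and stayed within the scatter, so it gave no such sign. Here, a change confined to the end of the side chain moves the number well beyond the scatter, but no measurement shown here explains why.

The compounds shown leave open whether a methoxy group, an amine, a carboxylic acid or a longer chain at this position would behave more like the 2-hydroxyethyl group of compound 2 or the 2-acetoxyethyl group of compound 4. They also leave open whether acetyl on the same oxygen would shift the number as far in compound 3, which carries 3,4-dichlorophenyl in place of 3,4-difluorophenyl.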